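The source may hold more compounds than are shown below. What is called first, only, known or untested is meant among the compounds shown, and "the series" means these compounds.

In a functional assay on MDA-MB-231 cells (Homo sapiens) for cytotoxicity, read by MTT assay, with a stated time of 72 h (a lower number here means a stronger inhibitor, a higher number a weaker inhibitor), the measured compounds stand as follows: compound 1 `CCN(CC)Cc1ccc2nc(NC(=O)N/N=C/c3cn(Cc4ccc(C)cc4)c4ccccc34)sc2c1` at 2010 nM; compound 2 `CCN(CC)Cc1ccc2nc(NC(=O)N/N=C/c3cn(Cc4ccc(Cl)cc4)c4ccccc34)sc2c1` at 2570 nM; compound 3 `CN(C)Cc1ccc2nc(NC(=O)N/N=C/c3cn(Cc4ccc(Cl)cc4)c4ccccc34)sc2c1` at 880 nM.

Compound 3 differs from compound 2 in its core by dimethylamino in place of diethylamino on a saturated chain carbon bound to an aromatic carbon, and that change gave a 2.9-fold lower number from compound 2 to compound 3 (0.47 log units; beyond the scatter). Compound 4 `Cc1ccc(Cn2cc(/C=N/NC(=O)Nc3nc4ccc(CN(C)C)cc4s3)c3ccccc32)cc1` has not yet been measured in this assay; it differs from compound 3 by methyl in place of chloro on an aromatic carbon. The same change has already been made once, from compound 2 to compound 1, (methyl in place of chloro on an aromatic carbon), where it gave a 1.3-fold lower number from compound 2 to compound 1 (0.11 log units; within the scatter).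

Compound 4 is therefore expected to give 700 nM, somewhere between 300 nM and 1600 nM. The step is estimated as a 1.3-fold lower number from compound 3 to compound 4 (0.10 log units; within the scatter), because compound 3 gives 880 nM and because the step of a 1.3-fold lower number from compound 2 to compound 1 (0.11 log units; within the scatter) stayed within the scatter.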

Compound 4, half-maximal inhibitory concentration: 1220 nM
Compound 4: middle estimate off by 1.7-fold (0.24 log units), on the low side, and the stated range covers the measured number.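

In this assay, methyl in place of chloro gave a 1.4-fold higher number from compound 3 to compound 4 (0.14 log units; within the scatter), and this step agrees with the one seen for the same change on the diethylamino compounds: the same change on two cores in this assay, a 1.3-fold lower number (0.11 log units; within the scatter) from compound 2 to compound 1 and a 1.4-fold higher number (0.14 log units; within the scatter) from compound 3 to compound 4, 1.8-fold (0.25 log units) apart, within the scatter of two such steps. Dimethylamino in place of diethylamino gave a 1.6-fold lower number from compound 1 to compound 4 (0.22 log units; within the scatter), which lies within the scatter, although the same change on the chloro compounds lay beyond it, and the two steps still do not differ beyond the scatter: the same change on two cores in this assay, a 2.9-fold lower number (0.47 log units; beyond the scatter) from compound 2 to compound 3 and a 1.6-fold lower number (0.22 log units; within the scatter) from compound 1 to compound 4, 1.8-fold (0.25 log units) apart, within the scatter of two such steps. Both changes therefore carry across these two cores without a detectable difference, but two pairs cannot exclude a dependence on the core smaller than the scatter.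

As far as these compounds go, it remains open how a methoxy group or a nitrile would compare with chloro and methyl on that aromatic carbon. From the compounds shown here alone, it also remains open whether a cyclic amine such as morpholine or a longer chain on the nitrogen would extend the trend seen with dimethylamino and diethylamino.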